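The compounds below may be only part of what the source reports. "The series", "measured", "known", "first", "only" and "open" are said of these compounds alone.

Compound 3 `COc1ccc(C(=O)NCc2ccc(CNS(=O)(=O)c3ccc(C)cc3)cc2)cc1` gives in an assay on MDA-MB-231 cells for binding affinity to C-X-C chemokine receptor type 4 (Homo sapiens), read by immunofluorescence and microscopy, with stated times of 10 min and 30 min (a lower number here means that less compound is needed, a higher number that more compound is needed for the effect), 100 nM. Of the two numbers in hand this is the higher one: compound 2 `Cc1ccc(S(=O)(=O)NCc2ccc(CNC(=O)c3ccc(F)cc3)cc2)cc1` gives 1 nM, a gap of a 100-fold higher number from compound 2 to compound 3 (2.00 log units; beyond the scatter). Compound 1 `Cc1ccc(S(=O)(=O)NCc2ccc(CNC(=O)c3ccccc3)cc2)cc1` reaches in this assay only a limit, > 1000 nM, and no number. Compound 4 `Cc1ccc(S(=O)(=O)NCc2ccc(CNC(=O)c3cccc(Cl)c3)cc2)cc1` differs from compound 3 in one place: 3-chlorophenyl in place of 4-methoxyphenyl on a carbonyl carbon. Among the measured compounds shown here, two measured steps touch this change. Methoxy in place of hydrogen gave an at least 10-fold lower number from compound 1 to compound 3 (1.00 log units; beyond the scatter), and fluoro gave a much lower number than methoxy, since a 100-fold higher number from compound 2 to compound 3 (2.00 log units; beyond the scatter) runs the other way. For the measured compounds named here, no measured step involves 3-chlorophenyl, so the expected 3.3-fold lower number from compound 3 to compound 4 (0.52 log units; beyond the scatter) is a modest lowering carrying wide uncertainty. Compound 4 is therefore estimated at 30 nM, between 3 nM and 300 nM.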

Compound 4, effective concentration (reported as EC, without a stated level of effect): 100 nM
Beside the measured number, compound 4's estimate is 3.3-fold (0.52 log units) below it; low and high end bracket the measured number.
By their numbers in this assay, from the lowest: compound 2; then compounds 3 and 4 (each within the scatter of the next). At a limit, above all of these: compound 1.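

In this assay, 3-chlorophenyl in place of 4-methoxyphenyl on this carbonyl carbon gives no change at the digits printed from compound 3 to compound 4 (within the scatter). A substituted ring again improves on the unsubstituted one, with an at least 10-fold lower number from compound 1 to compound 4 (1.00 log units; beyond the scatter), but that step starts from a limit and not a number: the limit of > 1000 nM in this assay, at which 1 of the 4 values shown sits. The 4-fluorophenyl group remains clearly ahead, with a 100-fold higher number from compound 2 to compound 4 (2.00 log units; beyond the scatter).

Still open, as far as these compounds go, is whether any other group, such as an amine or a carboxylic acid, could match fluoro on this ring. The 3-chlorophenyl and 4-methoxyphenyl groups differ in both substituent and its place on the ring, leaving the contribution of each unresolved.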